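The compounds below may be only part of what the source reports. "The series", "measured", "known", "first", "only" and "open" are said of these compounds alone.

Among the compounds with values here, compound 2 `O=C(c1ccc(F)cc1)N1CC(c2nc(-c3cccc(Cl)c3)no2)C1` is the only member of the series with a number in an assay on HEK293 cells for negative allosteric modulation of metabotropic glutamate receptor 5 (Homo sapiens), read by FLIPR; on this read-out higher numbers stand for weaker inhibition and lower numbers for stronger inhibition: in this assay compound 2 gives 4000 nM. Compound 1 `O=C(N1CCC(F)CC1)N1CC(c2nc(-c3cccc(Cl)c3)no2)C1` is reported only as a limit of this assay, (the limit of > 10000 nM in this assay, at which 1 of the 2 values shown sits); in this assay compound 1 gives > 10000 nM. Within the data shown here, the single measured step, an at least 2.5-fold lower number from compound 1 to compound 2 (0.39 log units; beyond the scatter), shows the gain on moving from a ring-amine urea to an aryl amide on the carbonyl carbon.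

Compound 3 `O=C(N1CCCCCC1)N1CC(c2nc(-c3cccc(Cl)c3)no2)C1` differs from compound 2 by azepan-1-yl in place of 4-fluorophenyl on a carbonyl carbon. This reverses the direction of the measured step, returning to a urea with a ring amine on the carbonyl carbon, so the expectation is a step back toward the limit, estimated at a 2.5-fold higher number from compound 2 to compound 3 (0.40 log units; beyond the scatter). Compound 3 is therefore expected to give 10000 nM in this assay, with a range from 4000 nM to 30000 nM, and a real chance that only a limit is reported.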

Compound 3, half-maximal inhibitory concentration: > 10000 nM
Compound 3: no number, only a limit; the forecaster's own chance of this, stated with the estimate: 55%; the middle value lies on the limit itself.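

In this assay, replacing the aryl amide with a second ring-amine urea gives an at least 2.5-fold higher number from compound 2 to compound 3 (0.39 log units; beyond the scatter), so the earlier gain on the carbonyl carbon now holds against two different ring amines, one with fluorine and one without. The azepan-1-yl and 4-fluorophenyl groups have the same heavy-atom count, so that count alone does not separate the aryl amide from this urea, and both ureas stop at a limit of the assay: the limit of > 10000 nM in this assay, at which 2 of the 3 values shown sit. The step between compound 1 and compound 3 cannot be read, as both values are limits.

Still open, from the compounds shown here alone, is whether the number of compound 2 moves further with an unsubstituted phenyl or a pyridine ring on the carbonyl carbon. Also open, going by these compounds, is whether an open-chain amine such as diethylamine behaves like the ring amines there.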